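The compounds below may be only part of what the source reports. "The series", "measured", "known", "first", "only" and "open" are said of these compounds alone.

For the measured compounds named here, compound 1 `CNc1nc(NCc2ccc(OC(F)(F)F)cc2)cc(-c2ccccn2)n1` is the more potent of the two compounds measured so far in a functional assay on HEK293 cells for agonist activity at G-protein coupled receptor 39 (Homo sapiens), read by inositol phosphate accumulation; a lower number here means that less compound is needed, a higher number that more compound is needed for the effect. In this assay compound 1 gives 13 nM, while compound 2 `CC(C)(C)CNc1nc(NCC2CC2)cc(-c2ccccn2)n1`, which carries a different pair of amine substituents on the shared core, gives 5000 nM, a gap that lies well beyond the usual scatter of the measurement. Going by the values given here, no single-point step connects these two, so nothing more is read from their pair than the two numbers themselves.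

Compound 3 `CNc1nc(NCc2ccc(NS(C)(=O)=O)cc2)cc(-c2ccccn2)n1` is the next compound to be measured in this assay. It differs from compound 1 in one place only: methanesulfonamido in place of trifluoromethoxy on an aromatic carbon. The substituent changes from one without a hydrogen-bond donor to one with a donor and an additional acceptor, and the sulfonamide brings two double bonds outside the aromatic rings.

On the evidence of the two compounds available, he expects the step from compound 1 to compound 3 to be a loss of potency of moderate size, a 12-fold higher number from compound 1 to compound 3 (1.06 log units; beyond the scatter), beyond the scatter but far smaller than the gap to compound 2. Compound 3 is accordingly estimated at 150 nM, with a range from 30 nM to 1000 nM.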

Compound 3, half-maximal effective concentration: 3 nM
Compound 3: middle estimate off by 50-fold (1.70 log units), on the high side; the measured number lies below the stated range.
By their numbers in this assay, from the lowest: compound 3; then compound 1; then compound 2.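

In this assay the exchange of trifluoromethoxy for methanesulfonamido, on an aromatic carbon para to a large group, gives a 4.3-fold lower number from compound 1 to compound 3 (0.64 log units; beyond the scatter), a modest step but one beyond the scatter. For the compounds shown here, it shows that this place accepts a group with a hydrogen-bond donor, an additional acceptor and two double bonds outside aromatic rings, and that the potency of compound 1 does not depend on keeping trifluoromethoxy there, since compound 3 is the lowest of the numbers so far. Nothing available bears on why the number falls with this exchange.

As far as these compounds go, whether the gain rests on the sulfonamide hydrogen, on the sulfonyl oxygens or on the group as a whole stays open, and a methanesulfonamido group with a methyl on its nitrogen, or an acetamido group, would be needed to separate these readings. Equally open, from the compounds shown here alone, is whether a plain amine or a carboxylic acid on this same aromatic carbon would keep the number near that of compound 3, and whether the step holds with other amine substituents on the shared core.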